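The source may report more compounds than this note shows. Statements on the series, on what has been measured and on what is new or still open speak of the compounds shown alone.

Compound 1 `COc1ccc(C(=O)c2ccc3c(ccn3S(=O)(=O)c3cccc(/C=C/C(=O)NO)c3)c2)cc1OC` was tested in an assay on isolated protein for inhibition of polyamine deacetylase HDAC10 (Homo sapiens) (a higher number here means a weaker inhibitor, a lower number a stronger inhibitor), and gives 8240 nM. Of the two plain numbers recorded in this assay it is the higher one, yet the nearest value, that of compound 2 `COc1ccc(C(=O)c2ccc3c(ccn3Cc3ccc(/C=C/C(=O)NO)cc3)c2)cc1`, which gives 7050 nM in this assay, lies within the scatter of repeated measurements, so the two cannot be told apart. Compound 3 `O=C(NO)c1ccc(Cn2ccc3cc(C(=O)c4ccc(Cl)cc4)ccc32)cc1` stands differently: in this assay compound 3 gives only > 100000 nM, which is a limit of the assay and not a number, as recorded in the limit of > 100000 nM in this assay, at which 1 of the 3 values shown sits.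

Compound 4 `O=C(/C=C/c1cccc(S(=O)(=O)n2ccc3cc(C(=O)c4ccc(F)cc4)ccc32)c1)NO` has not yet been measured in this assay. It keeps the shared core of compound 1, with its sulfonyl link and hydroxamic acid, and differs in one place: 4-fluorophenyl in place of 3,4-dimethoxyphenyl on a carbonyl carbon. Going by the values given here, no measured pair isolates this change, so its effect can only be expected rather than read off. Compound 1 and compound 2 differ in several places yet give numbers within the scatter of each other, which suggests this region is tolerant. The expected step is accordingly modest, a 1.0-fold lower number from compound 1 to compound 4 (0.01 log units; within the scatter), with no direction beyond the scatter. For compound 4 the estimated value in this assay is 8000 nM, with a range from 3000 nM to 25000 nM.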

Compound 4, half-maximal inhibitory concentration: 5240 nM
The estimate for compound 4 lay 1.5-fold (0.18 log units) above the measured number; low and high end bracket the measured number.
By their numbers in this assay, from the lowest: compounds 4, 2 and 1 (each within the scatter of the next). At a limit, above all of these: compound 3.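

In this assay, going by these compounds alone, the change from 3,4-dimethoxyphenyl to 4-fluorophenyl on a carbonyl carbon gives a 1.6-fold lower number from compound 1 to compound 4 (0.20 log units; within the scatter) and so is the first pair to isolate this position. With the rest of compound 1 kept, including the sulfonyl link and the hydroxamic acid, swapping these two groups leaves the number within the scatter, and neither group can be ranked over the other. Nothing recorded here bears on a cause for this step.

The compounds shown leave open whether this position would be as even with an amine or a carboxylic acid in place of the fluorine, or with a longer chain on the carbonyl carbon. They also leave open whether the same change would give so small a step on the core of compound 2.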